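Aryl replacement from compound 1 to compound 4

This account rests on a few compounds, and the source may have more. Where it says the series, first, only, none or still open, it means among the compounds named here.

Measured in a functional assay on Jurkat cells (Homo sapiens) for antiproliferative activity, read by MTT assay and trypan blue exclusion, with a stated time of 72 h; a lower number here means a stronger inhibitor, a higher number a weaker inhibitor:
- compound 1 `COC(=O)c1ccc(C2SCC(=O)N2c2ccc(N3CCN(Cc4cc(OC)c(OC)c(OC)c4)CC3)cn2)c(OC)c1`: 41000 nM
- compound 2 `COC(=O)c1ccc(C2SCC(=O)N2c2ccc(N3CCN(Cc4cccc(C)c4)CC3)cn2)c(OC)c1`: > 100000 nM (a limit)
- compound 3 `COC(=O)c1ccc(C2SCC(=O)N2c2ccc(N3CCN(Cc4cccc([N+](=O)[O-])c4)CC3)cn2)c(OC)c1`: 37400 nM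

Among the compounds with values here, compound 1 and compound 3 hold the only two numbers, and they lie within the scatter of each other. The next compound is compound 4 `COC(=O)c1ccc(C2SCC(=O)N2c2ccc(N3CCN(Cc4ccc(Cl)c(Cl)c4)CC3)cn2)c(OC)c1`, with 3,4-dichlorophenyl in place of 3,4,5-trimethoxyphenyl on a saturated chain carbon bound to an amine nitrogen in a ring.

Two measured steps replace the same group. These are a 1.1-fold lower number from compound 1 to compound 3 (0.04 log units; within the scatter) and an at least 2.4-fold higher number from compound 1 to compound 2 (0.38 log units; beyond the scatter). They disagree, so no step beyond the scatter is expected in this assay. The estimated step is a 1.1-fold lower number from compound 1 to compound 4 (0.03 log units; within the scatter). For compound 4 the expected value is 38000 nM, with an estimated range of 14000 nM to 90000 nM.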

Compound 4, half-maximal inhibitory concentration: 61000 nM
Beside the measured number, compound 4's estimate is 1.6-fold (0.21 log units) below it; low and high end bracket the measured number.
By their numbers in this assay, from the lowest: compounds 3, 1 and 4 (each within the scatter of the next). At a limit, above all of these: compound 2.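

In this assay, 3,4-dichlorophenyl carries no hydrogen-bond acceptors and fewer heavy atoms than 3,4,5-trimethoxyphenyl, yet the change is small: a 1.5-fold higher number from compound 1 to compound 4 (0.17 log units; within the scatter), and a 1.6-fold higher number from compound 3 to compound 4 (0.21 log units; within the scatter). Within the data shown here, on this saturated chain carbon, three different aryl groups in compounds 1, 3 and 4 now give numbers within the scatter of each other, and compound 2 is the one compound that does not join them. Compound 2 stands at a limit, so its comparison gives only a floor, an at least 1.6-fold lower number from compound 2 to compound 4 (0.21 log units; that floor lies within the scatter), and no firm order: the limit of > 100000 nM in this assay, at which 1 of the 4 values shown sits.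

Open, as far as these compounds go, is whether a pyridine ring or a cyclohexyl ring on this carbon would move the number beyond the scatter.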